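A few compounds are considered here, and "the series" means these few. Any claim that something is new, unique, unknown or untested is made for them only; others in the source may bear on it.

Compound 1 `C=C(C)C(CC[C@@]1(C)C(CC[C@H]2[C@]3(C)CC[C@H](O)C(C)(C)O[C@H]3CC[C@@]2(C)O)=C(C)CC[C@H]1O)OO` and compound 2 `CC1=C(CC[C@H]2[C@]3(C)CC[C@H](O)C(C)(C)O[C@H]3CC[C@@]2(C)O)[C@](C)(C/C=C/C(C)(C)O)[C@H](O)CC1` share one core and differ only in a side chain on a saturated chain carbon bound to a saturated ring carbon. In a functional assay on MDA-MB-231 cells (Homo sapiens) for antiproliferative activity, read by MTT assay, with a stated time of 72 h (on this read-out higher numbers stand for weaker inhibition and lower numbers for stronger inhibition), compound 1 gives > 50000 nM, which is a limit of the assay and not a number. In this assay compound 2 gives > 50000 nM, again a limit rather than a measured number. The step that the two limits leave unreadable from compound 1 to compound 2 therefore has no readable size, and all that can be said is the limit of > 50000 nM in this assay, at which 2 of the 2 values shown sit. Compound 3 `CC(C)=CCC[C@@]1(C)C(CC[C@H]2[C@]3(C)CC[C@H](O)C(C)(C)O[C@H]3CC[C@@]2(C)O)=C(C)CC[C@H]1O` is the compound still to be measured, and it differs from compound 2 in one place: 3-methylbut-2-en-1-yl in place of 3-hydroxy-3-methylbut-1-en-1-yl on a saturated chain carbon bound to a saturated ring carbon. Among the compounds with values here, no measured step bears on this change, because a step that the two limits leave unreadable from compound 1 to compound 2 cannot be read. There is thus no direction to expect beyond the scatter, and the most that can be expected is that compound 3 stays near the same limit. Compound 3 is estimated to give 50000 nM in this assay. The estimate for compound 3 is expected to lie between 10000 nM and 200000 nM. The expected step of a number no higher from compound 2 to compound 3 (the limit leaves the size open) is accordingly small and uncertain.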

Compound 3, half-maximal inhibitory concentration: > 50000 nM
Compound 3 gave a limit, no number; the forecaster's own chance of this, stated with the estimate: 70%; the middle value lies on the limit itself.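

In this assay compound 3 gives > 50000 nM, which is a limit of the assay and not a number. None of the steps among compound 1, compound 2 and compound 3 can therefore be read: the limit of > 50000 nM in this assay, at which 3 of the 3 values shown sit. The compounds shown leave open whether changing the side chain on the shared core affects antiproliferative activity at all.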